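The compounds below may be only part of what the source reports. "The series", "measured", "known", "first", "only" and "open" are said of these compounds alone.

Three close relatives have been measured in a physicochemical assay for acid dissociation, using potentiometric titration. Compound 1 `CCCN1CCN(c2cccc([N+](=O)[O-])c2)CC1` gives 7.7; compound 3 `CCCN1CCN(c2cccc(C#N)c2)CC1` gives 7.67; compound 2 `CCCN1CCN(c2ccc([N+](=O)[O-])cc2)CC1` gives 7.59. Compound 1 and compound 3 differ by cyano in place of nitro on an aromatic carbon, and the resulting step is a number 0.03 log units lower from compound 1 to compound 3 (within the scatter). The cores of compound 1 and compound 2 also differ, but that difference is not broken down here. Compound 4 `CCCN1CCN(c2ccc(C#N)cc2)CC1` has not yet been measured; it differs from compound 2 by cyano in place of nitro on an aromatic carbon. This is the same kind of change as the one seen before, though there the group sits meta to a group of 9 heavy atoms and here para to a group of 9 heavy atoms. Resting on the step of a number 0.03 log units lower from compound 1 to compound 3 (within the scatter), compound 4 is expected to show a number 0.03 log units lower from compound 2 to compound 4 (within the scatter). Compound 4 is therefore estimated at 7.56, plausibly between 7.3 and 7.85.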

Compound 4, acid dissociation constant: 7.78
Estimate against measurement, compound 4: 0.22 log units below; the measured number falls inside the stated range.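

In this assay cyano in place of nitro on an aromatic carbon gives a number 0.19 log units higher from compound 2 to compound 4 (within the scatter) and on the other core gives a number 0.03 log units lower from compound 1 to compound 3 (within the scatter) so neither core shows a step beyond the scatter. This shows that, in these two pairs, the change carries from one core to the other without a step the measurement can separate from scatter, but it does not show that the change would behave alike on any further core. No measurement bearing on the reason for either step is available here. The compounds shown leave open whether other groups in that place, such as an amine, a carboxylic acid or a longer chain, would also stay within the scatter.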